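Hydrazone series: methyl for trifluoromethyl, from compound 3 to compound 4

The compounds below may be only part of what the source reports. "The series", "measured", "known", "first", "only" and "open" are said of these compounds alone.

Compound 1 `CC(=O)/C(=N\Nc1ccccc1)Oc1cccc(Cl)c1`: > 10000 nM
Compound 2 `CC(=O)/C(=N\Nc1ccccc1C(F)(F)F)Nc1cccc(Cl)c1`: 538 nM; 538 nM (2 entries)
Compound 3 `CC(=O)/C(=N\Nc1ccccc1C(F)(F)F)N(C)c1cccc(Cl)c1`: > 10000 nM

In an assay on isolated protein for binding affinity to corticotropin-releasing factor receptor 1 (Homo sapiens) (a lower number here means a stronger inhibitor, a higher number a weaker inhibitor), compound 1 reports only a limit, > 10000 nM, not a number. Among the compounds with values here, compound 2 is the one member of the set with a measured number, 538 nM; 538 nM (2 entries) in this assay from two entries. Compound 3 likewise reports only a limit, > 10000 nM, in this assay. On the numbers shown compound 3 therefore stands at the weak end of the set, together with compound 1, at the limit of > 10000 nM in this assay, at which 2 of the 3 values shown sit; only compound 2 lies away from that limit.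

Compound 4 `CC(=O)/C(=N\Nc1ccccc1C)N(C)c1cccc(Cl)c1` is not yet measured. It differs from compound 3 by methyl in place of trifluoromethyl on an aromatic carbon. Within the data shown here, no measured pair in the set covers this change, so its size has to be estimated. Among the measured compounds shown here, compound 3 gives no number to move from, and the methyl replacing the trifluoromethyl is the only change, so compound 4 is expected to remain at the limit, with the expected step from compound 3 to compound 4 in this assay being a step that the limit leaves unreadable from compound 3 to compound 4, nothing beyond the scatter. For compound 4 the estimate in this assay is 15000 nM, within 3000 nM to 60000 nM.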

Compound 4, inhibition constant: > 10000 nM
Compound 4: only a limit was reported (the forecaster's own chance of this, stated with the estimate: 80%); the middle value is on the limit's open side.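

Compound 3 and compound 4 both report only a limit in this assay, and the step between them cannot be read: the limit of > 10000 nM in this assay, at which 3 of the 4 values shown sit.

The compounds shown leave open how far either compound lies past that limit, and whether methyl in place of trifluoromethyl on an aromatic carbon changes the read-out in this assay at all.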